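This account rests on a few compounds, and the source may have more. Where it says the series, first, only, none or still open, it means among the compounds named here.

Measured compounds:
compound 1 `FC(F)(F)c1ccc(CSc2nc(N3CCCCC3)c3ccccc3n2)cc1` gives 28400 nM in a functional assay on MDA-MB-231 cells (Homo sapiens) for cytotoxicity, read by MTT assay, with a stated time of 72 h; a lower number here means a stronger inhibitor, a higher number a weaker inhibitor
compound 2 `CCOc1ccccc1Nc1nc(SCc2ccc(C(F)(F)F)cc2)nc2ccccc12` gives > 50000 nM, a limit of the assay and not a number

Among the measured compounds shown here, compound 1 stands at the only number this assay has produced so far; the other value, that of compound 2, is a limit. Compound 3 `O=[N+]([O-])c1cccc(Nc2nc(SCc3ccc(C(F)(F)F)cc3)nc3ccccc23)c1` differs from compound 1 by (3-nitrophenyl)amino in place of piperidin-1-yl on an aromatic carbon. For the measured compounds named here, the single measured step that bears on it is an at least 1.7-fold higher number from compound 1 to compound 2 (0.24 log units; that floor lies within the scatter), where (2-ethoxyphenyl)amino replaces the same piperidin-1-yl; that step is known only as a floor, because compound 2 sits at the limit of > 50000 nM in this assay, at which 1 of the 2 values shown sits. Since (3-nitrophenyl)amino, like (2-ethoxyphenyl)amino, places a substituted phenyl amine where piperidin-1-yl was, a move toward a higher number is expected, its size bounded only from below. Compound 3 is expected to give 50000 nM, between 20000 nM and 150000 nM, with a fair chance that only a limit is reported. This amounts to an expected step of a 1.8-fold higher number from compound 1 to compound 3 (0.25 log units; within the scatter).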

Compound 3, half-maximal inhibitory concentration: 31500 nM
Compound 3: the middle estimate sits 1.6-fold (0.20 log units) above what was measured; the measured number falls inside the stated range.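

At this aromatic carbon of the shared core, (3-nitrophenyl)amino gives a readable number in this assay, and the step is a 1.1-fold higher number from compound 1 to compound 3 (0.04 log units; within the scatter): swapping piperidin-1-yl for this group, with its aromatic ring and hydrogen-bond donor, leaves no change that can be told from scatter. Exchanging the substituent on the nitrogen gives an at least 1.5-fold lower number from compound 2 to compound 3 (0.20 log units; that floor lies within the scatter), so no difference between 3-nitrophenyl and 2-ethoxyphenyl is established. The value of compound 2 remains a limit of the assay and not a number: the limit of > 50000 nM in this assay, at which 1 of the 3 values shown sits.

Still open, on these data alone, is whether any group at this carbon moves the number beyond the scatter. A piperazine, a morpholine or an unsubstituted phenylamino group would test whether the ring on this position matters at all.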